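The source may report more compounds than this note shows. Statements on the series, on what has been measured and on what is new or still open speak of the compounds shown alone.

Three compounds share one core and differ only in the group attached to one aromatic carbon of that core. Compound 1 `COc1ccc(Nc2cc(C)nc(SCc3nc4ccccc4[nH]3)n2)cc1` carries a (4-methoxyphenyl)amino group there, and in a functional assay on PC-3 cells (Homo sapiens) for cytotoxicity, read by MTT assay, with a stated time of 72 h (a lower number here means a stronger inhibitor, a higher number a weaker inhibitor), compound 1 gives 67400 nM. Compound 2 `Cc1cc(N2CCNCC2)nc(SCc2nc3ccccc3[nH]2)n1` carries piperazin-1-yl instead; in this assay compound 2 reaches only the limit > 100000 nM, which is a boundary of the assay and not a number. Compound 3 `Cc1cc(NNC(N)=S)nc(SCc2nc3ccccc3[nH]2)n1` keeps the amino nitrogen but carries a short open chain on it; in this assay compound 3 likewise sits at the limit > 100000 nM. Compound 3 thus stands at the limit of > 100000 nM in this assay, at which 2 of the 3 values shown sit.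

Compound 4 `Cc1cc(Nc2ccc(Br)cc2)nc(SCc2nc3ccccc3[nH]2)n1` has not been measured. From compound 3 to compound 4 the change is a group of 7 heavy atoms (6 carbon, 1 bromine; one six-membered aromatic ring of carbon only) in place of a group of 4 heavy atoms (1 carbon, 2 nitrogen, 1 sulfur; no ring), on a nitrogen on an aromatic ring. The closest measured step is an at least 1.4-fold higher number from compound 1 to compound 3 (0.17 log units; that floor lies within the scatter), which runs the same exchange in reverse, and an at least 1.4-fold higher number from compound 1 to compound 2 (0.17 log units; that floor lies within the scatter) points the same way. Read backwards, a modest drop in the number is expected, though the floor of that step lies within the scatter. Compound 4 is therefore expected to give about 60000 nM, between 20000 nM and 150000 nM. That estimate means an expected step of an at least 1.6-fold lower number from compound 3 to compound 4 (0.22 log units; that floor lies within the scatter).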

Compound 4, half-maximal inhibitory concentration: 37100 nM
Compound 4: the middle estimate sits 1.6-fold (0.21 log units) above what was measured; the range from low to high includes it.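

In this assay, a ring on the amino nitrogen now separates clearly from the open chain and from piperazin-1-yl: the exchange for the open chain gives an at least 2.6-fold lower number from compound 3 to compound 4 (0.43 log units; beyond the scatter), and the exchange for piperazin-1-yl gives an at least 2.6-fold lower number from compound 2 to compound 4 (0.43 log units; beyond the scatter). Compound 2 and compound 3 are limits of the assay and not numbers, so both steps give only a floor for the size of the change: the limit of > 100000 nM in this assay, at which 2 of the 4 values shown sit. Bromo in place of methoxy on an aromatic carbon gives a 1.8-fold lower number from compound 1 to compound 4 (0.26 log units; within the scatter), so the two compounds with a ring on that nitrogen cannot be told apart here.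

From the compounds shown here alone, whether an unsubstituted phenyl, or a chloro or nitro group on the ring, would read differently stays open. So does the reading of a benzyl group on that nitrogen.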